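A few compounds are considered here, and "the series" means these few. Any claim that something is new, unique, unknown or untested is made for them only; others in the source may bear on it.

Going by the values given here, compound 1 `CCc1ccc(Nc2cc(NC(=O)Nc3cc(OC)cc(OC)c3)ncn2)cc1` is one of three compounds measured in a functional assay on NCI-H1581 cells (Homo sapiens) for inhibition, read by MTT assay, with a stated time of 48 h, tested at 10 uM; on this read-out higher numbers stand for more inhibition at the one concentration tested (going by the name of the read-out) and lower numbers for less inhibition. Compound 1 gives 32.7% and is the lowest of the three; its nearest neighbour on the numbers is compound 3 `COc1cc(Br)ccc1Nc1cc(NC(=O)Nc2c(Cl)cccc2Cl)ncn1`, which gives 47.3%, and the furthest is compound 2 `Cc1ccc(Nc2cc(NC(=O)Nc3c(Cl)cccc3Cl)ncn2)cc1C`, which gives 73.3%. Both gaps to compound 1 lie beyond the scatter.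

Compound 4 `COc1cc(NC(=O)Nc2cc(Nc3ccc(OC)c(I)c3)ncn2)cc(OC)c1` has not been measured. It differs from compound 1 in one place: 3-iodo-4-methoxyphenyl in place of 4-ethylphenyl on a nitrogen on an aromatic ring.

Among the compounds with values here, only one measured step bears on this change. Going from compound 2 to compound 3 also swaps an alkyl-substituted phenyl for a halogen- and methoxy-bearing phenyl on the nitrogen on the aromatic ring, and there a number 26 percentage points lower from compound 2 to compound 3 (beyond the scatter). That swap sits on a different urea partner, and the substituents are placed differently, so it carries over only loosely. It still points toward a lower or unchanged number rather than a higher one, and compound 1 already starts low.

Compound 4 is therefore expected to give about 25%, within 5% to 48%, which would mean an estimated a number 7.7 percentage points lower from compound 1 to compound 4 (within the scatter) that may well stay inside the scatter.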

Compound 4, a percentage reported as inhibition, at one concentration (the size of the read-out at that concentration, not a potency): 43%
Compound 4: middle estimate off by 18 percentage points, on the low side; low and high end bracket the measured number.
By their numbers in this assay, from the lowest: compound 1; then compounds 4 and 3 (each within the scatter of the next); then compound 2.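

In this assay, replacing 4-ethylphenyl with 3-iodo-4-methoxyphenyl on the nitrogen on an aromatic ring gives a number 10.3 percentage points higher from compound 1 to compound 4 (beyond the scatter), so on the urea partner of compound 1 an aryl group carrying a halogen and a methoxy group can raise the number. Going by these compounds alone, the only earlier step at this place, a number 26 percentage points lower from compound 2 to compound 3 (beyond the scatter), ran the other way, but it involved different groups on a different urea partner, so the two steps together show that a swap of this broad kind has no single direction here. No available evidence explains this rise or the difference between the two steps.

The iodo and methoxy groups enter together, so the compounds shown leave open how much of the step belongs to each, and whether 3-iodo-4-methoxyphenyl would also raise the number on the urea partner of compound 2. They also leave open how the read-out would respond to an amine, a carboxylic acid or a longer alkyl chain on this phenyl ring.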